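Nitro in Place of Methoxy: Expectation for Compound 4

A few compounds are considered here, and "the series" means these few. Any claim that something is new, unique, unknown or untested is made for them only; others in the source may bear on it.

The measured compounds and their numbers in a functional assay on PANC-1 cells (Homo sapiens) for inhibition, read by MTT assay, with a stated time of 24 h, tested at 10 uM; on this read-out lower numbers stand for less inhibition and higher numbers for more inhibition at the one concentration tested (going by the name of the read-out):
Compound 1 `CC(C)=CCC/C(C)=C/CC1Cc2c(OCCCNC(=O)c3ccco3)cc(=O)n(CCCO)c2CC1(C)C`: 2.8%
Compound 2 `CC(C)=CCC/C(C)=C/CC1Cc2c(OCCCNC(=O)c3cccs3)cc(=O)n(CCCO)c2CC1(C)C`: 11.5%
Compound 3 `COc1ccc(OCCCOc2cc(=O)n(CCCO)c3c2CC(C/C=C(\C)CCC=C(C)C)C(C)(C)C3)cc1`: 0%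

All three compounds share one core and differ only in the group at the end of the three-carbon chain on the aromatic oxygen. Compound 3 stands at the bottom of the three numbers, though one of its gaps is a number 2.8 percentage points lower from compound 1 to compound 3 (within the scatter), which is within the scatter, while the other is a number 11.5 percentage points lower from compound 2 to compound 3 (beyond the scatter), a modest step beyond it. Within the data shown here, none of the measured compounds does much in this assay.

Compound 4 `CC(C)=CCC/C(C)=C/CC1Cc2c(OCCCOc3ccc([N+](=O)[O-])cc3)cc(=O)n(CCCO)c2CC1(C)C` is the untested member. Relative to compound 3 the change is nitro in place of methoxy on an aromatic carbon. Among the measured compounds shown here, no measured step touches this kind of exchange: the steps of a number 8.7 percentage points higher from compound 1 to compound 2 (within the scatter), a number 2.8 percentage points lower from compound 1 to compound 3 (within the scatter) and a number 11.5 percentage points lower from compound 2 to compound 3 (beyond the scatter) all concern the group at the end of the chain as a whole, and only one of them exceeds the scatter. With compound 3 at the floor of the assay and every neighbour low, a swap of one substituent on the phenoxy ring is expected to give at most a small shift, a number 4 percentage points higher from compound 3 to compound 4 (within the scatter), not beyond the scatter. Compound 4 is therefore estimated at 4%, with a range from 0% to 15%.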

Compound 4, a percentage reported as inhibition, at one concentration (the size of the read-out at that concentration, not a potency): 9.8%
Compound 4: the middle estimate sits 5.8 percentage points below what was measured, within the range that was stated.
By their numbers in this assay, from the lowest: compounds 3, 1, 4 and 2 (each within the scatter of the next, the first and the last beyond it).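

In this assay the only exchange shown on the phenoxy ring itself, nitro in place of methoxy on an aromatic carbon para to a large group, gives a number 9.8 percentage points higher from compound 3 to compound 4 (within the scatter) and so does not carry the number out of the scatter. Against the two amides, the 4-nitrophenoxy end group gives a number 1.7 percentage points lower from compound 2 to compound 4 (within the scatter) and a number 7 percentage points higher from compound 1 to compound 4 (within the scatter), whereas the 4-methoxyphenoxy end group gave a number 11.5 percentage points lower from compound 2 to compound 3 (beyond the scatter); the one gap beyond the scatter among the earlier compounds therefore does not recur for the 4-nitrophenoxy end group. No independent evidence bears on this result, so the numbers stand without an explanation.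

With only methoxy and nitro shown on this ring carbon, it remains open whether an amine, a carboxylic acid or a chlorine at the same place would give a step beyond the scatter. Also open, on these data alone, is what a longer chain between the aromatic oxygen and the phenoxy group would do, and whether any such change would lift the number well above the low values seen so far at the one concentration tested.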